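Lengthening the linker chain by one more carbon

The source may report more compounds than this note shows. Statements on the series, on what has been measured and on what is new or still open speak of the compounds shown alone.

Compound 2 `N=C(N)c1ccc2oc(-c3ccc(OCCCCCOc4ccccc4)cc3)cc2c1` gives 4200 nM in an ADME assay on L6 cells (Rattus norvegicus) for cytotoxicity, read by resazurin assay, with a stated time of 70 h (a lower number here means a stronger inhibitor, a higher number a weaker inhibitor), the lowest of the two numbers measured; compound 1 `N=C(N)c1ccc2oc(-c3ccc(OCCCOc4ccccc4)cc3)cc2c1` gives 7300 nM, a gap within the scatter. Compound 3 `N=C(N)c1ccc2oc(-c3ccc(OCCCCCCOc4ccccc4)cc3)cc2c1` is not yet measured. It differs from compound 2 by phenoxymethyl in place of phenoxy on a saturated chain carbon, five bonds along the chain from an oxygen on an aromatic ring. For the measured compounds named here, the only measured step of this kind, a 1.7-fold lower number from compound 1 to compound 2 (0.24 log units; within the scatter), stayed within the scatter, so no change beyond the scatter is expected in this assay for compound 3. Compound 3 is therefore estimated at 3500 nM, with a range from 1500 nM to 8000 nM, a step of a 1.2-fold lower number from compound 2 to compound 3 (0.08 log units; within the scatter).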

Compound 3, half-maximal inhibitory concentration: 3300 nM
Estimate against measurement, compound 3: 1.1-fold (0.03 log units) above, and the stated range covers the measured number.
By their numbers in this assay, from the lowest: compounds 3, 2 and 1 (each within the scatter of the next, the first and the last beyond it).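

In this assay, phenoxymethyl in place of phenoxy at this chain position gives a 1.3-fold lower number from compound 2 to compound 3 (0.10 log units; within the scatter), so this single change is too small to read on its own. Taken together, the chain extensions show more: 3-phenoxypropyl in place of phenoxy gives a 2.2-fold lower number from compound 1 to compound 3 (0.34 log units; beyond the scatter), the first difference here to clear the scatter, though only modestly. Nothing available explains this difference.

From the compounds shown here alone, whether a longer chain would take the number lower still remains open. So does the effect of an amine or a carboxylic acid in place of the phenoxy group.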